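The compounds below may be only part of what the source reports. "The series", "measured", "known", "first", "only" and "open" are said of these compounds alone.

Measured so far in a functional assay on HepG2 cells (Homo sapiens) for cytotoxicity, read by MTT assay; on this read-out lower numbers stand for stronger inhibition and higher numbers for weaker inhibition:
compound 1, `COc1ccc(/C=C/C(=O)c2ccc(OC)c3c2OC(C)(C)C=C3)cc1OC(=O)C(C)C` — 250 nM
compound 2, `COc1ccc(/C=C/C(=O)Oc2cc(/C=C/C(=O)c3ccc(OC)c4c3OC(C)(C)C=C4)ccc2OC)cc1` — 430 nM

Of the two numbers shown, compound 1 gives the smaller one, but the only measured step, a 1.7-fold higher number from compound 1 to compound 2 (0.24 log units; within the scatter), is within the scatter, so the two compounds are not told apart by this assay. That step swaps the group on the carbonyl carbon of the ester while the rest of compound 1 is kept.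

Compound 3, `COc1ccc(/C=C/C(=O)c2ccc(OC)c3c2OC(C)(C)C=C3)cc1CS(C)(=O)=O`, differs from compound 1 as follows: (methylsulfonyl)methyl in place of (isopropylcarbonyl)oxy on an aromatic carbon. Within the data shown here, no measured step bears directly on this change; the ester itself is removed, and the one step available, a 1.7-fold higher number from compound 1 to compound 2 (0.24 log units; within the scatter), only varied what hung from it and stayed within the scatter. With nothing shown beyond the scatter, no step beyond the scatter is expected here either, in either direction. Compound 3 is therefore estimated at 300 nM, within 100 nM to 900 nM. The expected step is a 1.2-fold higher number from compound 1 to compound 3 (0.08 log units; within the scatter).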

Compound 3, half-maximal inhibitory concentration: 9180 nM
Estimate against measurement, compound 3: 31-fold (1.49 log units) below, outside the stated range (above it).
By their numbers in this assay, from the lowest: compounds 1 and 2 (each within the scatter of the next); then compound 3.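

In this assay, among these compounds, the aromatic carbon carrying (isopropylcarbonyl)oxy is sensitive to what sits there: (methylsulfonyl)methyl in its place gives a 37-fold higher number from compound 1 to compound 3 (1.56 log units; beyond the scatter) and is the first change to reach beyond the scatter. Compound 1 and compound 2 varied only the group on the ester carbonyl carbon and were not told apart, whereas compound 3 removes the ester altogether, and the loss of activity comes with no change in the hydrogen-bond donor or acceptor counts of the exchanged groups. No measurement at hand explains this step.

As far as these compounds go, compound 3 replaces the ester linkage and the group it carries in a single change, so the contribution of each remains open. A free hydroxyl, an aminomethyl or a carboxylic acid on this aromatic carbon would help to separate the two.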